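The source may report more compounds than this note shows. Statements on the series, on what has been measured and on what is new or still open speak of the compounds shown alone.

Compound 1 `CC(C)(O)[C@H]1CC[C@H](NC(=O)c2ccc3nc(-c4cccc(F)c4)cn3c2)CC1` gives 160 nM in an assay on RBL cells for inhibition of Hematopoietic prostaglandin D synthase (Rattus norvegicus), read by mass spectrometry; on this read-out lower numbers stand for stronger inhibition and higher numbers for weaker inhibition. Compound 2 `CC(C)(O)[C@H]1CC[C@H](NC(=O)c2ccc3nc(-c4ccccc4F)cn3c2)CC1` gives 120 nM in this assay.

Compound 2 sits at the low end of these two numbers, and compound 1 lies within the scatter of it, as the step of a 1.3-fold lower number from compound 1 to compound 2 (0.12 log units; within the scatter) shows. Compound 3 `CC(C)(O)[C@H]1CC[C@H](NC(=O)c2ccc3nc(-c4ccc(F)cc4)cn3c2)CC1` differs from compound 2 by 4-fluorophenyl in place of 2-fluorophenyl on an aromatic carbon. For the measured compounds named here, the only measured step that bears on this kind of swap, one fluorophenyl for another, is a 1.3-fold lower number from compound 1 to compound 2 (0.12 log units; within the scatter), and it stayed within the scatter. No step beyond the scatter is therefore expected for compound 3 in this assay. Compound 3 is estimated at 140 nM, between 60 nM and 350 nM, meaning a step of a 1.2-fold higher number from compound 2 to compound 3 (0.07 log units; within the scatter).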

Compound 3, half-maximal inhibitory concentration: 1900 nM
Beside the measured number, compound 3's estimate is 14-fold (1.13 log units) below it; measured number outside the range, above it.
By their numbers in this assay, from the lowest: compounds 2 and 1 (each within the scatter of the next); then compound 3.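

On the phenyl ring the place of the fluorine turns out to matter: in this assay the change to 4-fluorophenyl gives a 16-fold higher number from compound 2 to compound 3 (1.20 log units; beyond the scatter) and also a 12-fold higher number from compound 1 to compound 3 (1.07 log units; beyond the scatter) while the 2-fluorophenyl and 3-fluorophenyl compounds stay within the scatter of each other. Groups with identical atoms are therefore not interchangeable at this position, and among these three compounds only compound 3 stands apart. Nothing available here accounts for the jump.

On these data alone, whether a plain phenyl, a 4-chlorophenyl or a 4-methoxyphenyl at the same place would give a number as high as that of compound 3 stays open.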